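The source may hold more compounds than are shown below. What is called first, only, known or untested is meant among the compounds shown, and "the series" means these compounds.

Measured so far in a functional assay on KARPAS-422 cells (Homo sapiens) for inhibition, read by CCK-8 assay; a higher number here means a weaker inhibitor of growth, a lower number a stronger inhibitor of growth:
compound 1, `O=S(=O)(Nc1cc(-c2cnc3[nH]cc(-c4ccncc4)c3c2)cnc1Cl)c1ccccc1F`, gives 350 nM;
compound 2, `O=S(=O)(Nc1cc(-c2cnc3[nH]cc(-c4ccccc4)c3c2)cnc1Cl)c1ccccc1`, gives 1830 nM;
compound 3, `O=S(=O)(Nc1cc(-c2cnc3[nH]cc(-c4ccncc4)c3c2)cnc1Cl)c1ccc(F)cc1`, gives 370 nM.

Among these three numbers compound 3 holds the second highest. Its nearest neighbour is compound 1, separated from it by a gap within the scatter; the furthest is compound 2, which sits higher by a gap beyond the scatter. Compound 2, however, differs from compound 3 in two places, on the sulfonyl sulfur and on the shared core, so its value shows only a combined effect and cannot be laid at the door of either change alone.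

The step to compound 4, `O=S(=O)(Nc1cc(-c2cnc3[nH]cc(-c4ccncc4)c3c2)cnc1Cl)c1ccccc1`, is hydrogen in place of fluoro on an aromatic carbon. For the measured compounds named here, the one measured step that touches the aryl group on the sulfonyl sulfur is a 1.1-fold higher number from compound 1 to compound 3 (0.02 log units; within the scatter), which lies within the scatter. Going by the values given here, no measured pair isolates the loss of the fluorine itself. On this basis the number in this assay for compound 4 is expected to stay close to that of compound 3. Relative to compound 3, compound 4 is expected to show a step of a 1.2-fold higher number from compound 3 to compound 4 (0.09 log units; within the scatter) in this assay. Compound 4 is therefore estimated at 450 nM, with a range from 200 nM to 1100 nM.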

Compound 4, concentration for 50% growth inhibition: 120 nM
Beside the measured number, compound 4's estimate is 3.8-fold (0.57 log units) above it, and the stated range ends above it.
By their numbers in this assay, from the lowest: compound 4; then compounds 1 and 3 (each within the scatter of the next); then compound 2.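

Within this assay, hydrogen in place of fluoro on the aryl group on the sulfonyl sulfur gives a step beyond the scatter from either fluorinated compound (a 3.1-fold lower number from compound 3 to compound 4 (0.49 log units; beyond the scatter); a 2.9-fold lower number from compound 1 to compound 4 (0.46 log units; beyond the scatter)). The earlier comparison between 2-fluorophenyl and 4-fluorophenyl (a 1.1-fold higher number from compound 1 to compound 3 (0.02 log units; within the scatter)) stayed within the scatter, so it could not show that the unsubstituted phenylsulfonyl group stands apart from both. With phenylsulfonyl now held fixed, pyridin-4-yl in place of phenyl on the shared core can also be read alone as a large step (a 15-fold lower number from compound 2 to compound 4 (1.18 log units; beyond the scatter)), and nothing in hand explains either change.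

From the compounds shown here alone, only fluoro and hydrogen are seen on the phenyl ring of the sulfonyl group, so what a methyl group, a methoxy group or a chlorine atom there would do remains open. Also open, going by these compounds, is whether an amine or a carboxylic acid in place of pyridin-4-yl on the shared core would keep the number low, and whether the step on losing fluoro would recur with phenyl at that place.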